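A few compounds are considered here, and "the series" means these few. Any claim that something is new, unique, unknown or untested is made for them only; others in the source may bear on it.

Measured so far in a physicochemical assay for solubility, read by turbidimetry, measured as kinetic solubility, at pH 7.4; a lower number here means a less soluble compound, a higher number a more soluble compound:
- compound 1 `CC1SC(c2cccc(C(=O)NCCCCc3ccccc3)c2)N(c2ccc(C3CC3)cc2)C1=O` gives 2000 nM
- compound 2 `O=C(NCCCCc1ccccc1)c1cccc(C2SCC(=O)N2c2ccc(C3CC3)cc2)c1` gives 2000 nM

Compound 1 stands level with compound 2, its nearest and only measured neighbour. The next entry is compound 3 `COc1ccccc1N1C(=O)C(C)SC1c1cccc(C(=O)NCCCCc2ccccc2)c1`, with 2-methoxyphenyl in place of 4-cyclopropylphenyl on an amide-type nitrogen in a ring. Among the compounds with values here, the one measured step (no change at the digits printed from compound 1 to compound 2 (within the scatter)) bears on this only indirectly. It is hydrogen in place of methyl on a saturated ring carbon, so it gives no measured size for an exchange on that nitrogen. Within the data shown here, no compound yet tests that exchange, and the data offer no basis for a direction. In this assay no step beyond the scatter is therefore expected, and the estimated step is (a 1.3-fold higher number from compound 1 to compound 3 (0.10 log units; within the scatter)). The estimate for compound 3 is (2500 nM within 1000 nM to 6000 nM).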

Compound 3, solubility: 10000 nM
Compound 3: the middle estimate sits 4.0-fold (0.60 log units) below what was measured, outside the stated range (above it).
By their numbers in this assay, from the lowest: compounds 1 and 2 (each within the scatter of the next); then compound 3.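

In this assay, within the data shown here, the aryl group on the amide-type nitrogen in a ring is the first place to give a step beyond the scatter: 2-methoxyphenyl in place of 4-cyclopropylphenyl gives a 5.0-fold higher number from compound 1 to compound 3 (0.70 log units; beyond the scatter) and the methyl exchange on the saturated ring carbon gives only no change at the digits printed from compound 1 to compound 2 (within the scatter) in the same core. The exchange removes the three-membered ring and brings in a hydrogen-bond acceptor, so this nitrogen substituent now has a measured effect on the read-out, though from a single pair. No supporting measurement accounts for the step.

Among these compounds, the single exchange cannot separate loss of the cyclopropyl group from gain of the methoxy group, and an unsubstituted phenyl would help divide the two. Also open, going by these compounds, are whether the step holds without the ring methyl and how a phenyl carrying an amine would read at this position.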